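Adding a fourth fluorine to the aryl ring of compound 3

This account rests on a few compounds, and the source may have more. Where it says the series, first, only, none or still open, it means among the compounds named here.

Measured compounds:
- Compound 1, `CC(C)(C)n1ncc(OCc2nnc(-c3c(F)c(F)c(F)c(F)c3F)o2)c(Cl)c1=O`: 271 ug/mL
- Compound 2, `COc1c(F)c(F)cc(-c2nnc(COc3cnn(C(C)(C)C)c(=O)c3Cl)o2)c1F`: a limit, > 300 ug/mL
- Compound 3, `CC(C)(C)n1ncc(OCc2nnc(-c3cc(F)c(F)cc3F)o2)c(Cl)c1=O`: 75.7 ug/mL

Of the compounds shown here, three sharing one core have been tested in a functional assay on the whole organism for inhibition, with Mythimna separata as the target, with a stated time of 5 days; a higher number here means that more compound is needed for the effect, a lower number that less compound is needed. Compound 3 has the lowest number of the two that were read as numbers; compound 1 sits above it by a margin beyond the scatter. Compound 2 gave only a limit of the assay, (the limit of > 300 ug/mL in this assay, at which 1 of the 3 values shown sits).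

For the measured compounds named here, the only step between single-change neighbours is an at least 3.9-fold lower number from compound 2 to compound 3 (0.59 log units; beyond the scatter), so removing the methoxy group helped clearly. Compound 4, `CC(C)(C)n1ncc(OCc2nnc(-c3cc(F)c(F)c(F)c3F)o2)c(Cl)c1=O`, is not yet measured. It differs from compound 3 by fluoro in place of hydrogen on an aromatic carbon.

Going by the values given here, no measured step tests exactly this change. Compound 1 carries more fluorines than compound 3 and gives a higher number, but the two differ in more than one place, so this is only a hint. The expectation for compound 4 is therefore a modest rise, a 1.8-fold higher number from compound 3 to compound 4 (0.27 log units; within the scatter), landing between the values of compound 3 and compound 1. The estimate for compound 4 is 140 ug/mL, with a range of 55 ug/mL to 300 ug/mL.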

Compound 4, half-maximal effective concentration: 241 ug/mL
Compound 4: the middle estimate sits 1.7-fold (0.24 log units) below what was measured; low and high end bracket the measured number.
By their numbers in this assay, from the lowest: compound 3; then compounds 4 and 1 (each within the scatter of the next). At a limit, above all of these: compound 2.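

For the compounds shown here, this is the first single-change test of fluoro in place of hydrogen on this ring in this assay, and it gives a 3.2-fold higher number from compound 3 to compound 4 (0.50 log units; beyond the scatter). So a fluoro on this aromatic carbon, ortho to two fluoro groups, is not tolerated as well as hydrogen, and the higher number of compound 1 can now be tied to this position rather than to its fluorine count alone. Hydrogen in place of fluoro on an aromatic carbon gives a 1.1-fold lower number from compound 1 to compound 4 (0.05 log units; within the scatter), so this exchange shows no difference that can be told from the scatter. Fluoro in place of methoxy on an aromatic carbon gives an at least 1.2-fold lower number from compound 2 to compound 4 (0.09 log units; that floor lies within the scatter). Compound 2 is a limit, so this step cannot be read beyond that floor: the limit of > 300 ug/mL in this assay, at which 1 of the 4 values shown sits.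

The compounds shown leave open whether a methyl group or an amine on this same carbon would behave like fluoro or like hydrogen. They also leave open how a chlorine there would compare.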